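Swapping a hydroxyalkyl arm for a methoxybenzyl arm

A few compounds are considered here, and "the series" means these few. Any claim that something is new, unique, unknown or untested is made for them only; others in the source may bear on it.

Compound 2 `CC(C)(CO)NCc1nc2c(OCC3CCCCC3)cccc2[nH]1` and compound 1 `OCCCNCc1nc2c(OCC3CCCCC3)cccc2[nH]1` share one core and differ only on an amine nitrogen. In an assay on cells for inhibition of interleukin-5 receptor subunit alpha (Mus musculus), read by WST assay, with a stated time of 48 h, in the presence of a further agent that is not named here (on this read-out lower numbers stand for stronger inhibition and higher numbers for weaker inhibition), compound 2 gives 27500 nM, and compound 1 gives 28500 nM; the step of a 1.0-fold lower number from compound 1 to compound 2 (0.02 log units; within the scatter) is within the scatter, so the two stand level. Compound 3 `COc1ccc(CNCc2nc3c(OCC4CCCCC4)cccc3[nH]2)cc1` carries 4-methoxybenzyl in place of 1-(hydroxymethyl)-1-methylethyl on an amine nitrogen. Going by the values given here, that measured step only swapped one hydroxyalkyl arm for another, whereas here a hydroxyl donor leaves and an aromatic ring enters, so no measured step bears directly on it. Compound 3 is therefore expected to give 18000 nM, between 5000 nM and 60000 nM, a step of a 1.5-fold lower number from compound 2 to compound 3 (0.18 log units; within the scatter) that is expected to stay near the scatter.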

Compound 3, half-maximal inhibitory concentration: > 30000 nM
Compound 3: a limit, no number; the forecaster's own chance of this, stated with the estimate: 10%; middle value at least 1.6-fold (0.22 log units) from the limit.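

In this assay compound 3 gives > 30000 nM, which is a limit of the assay and not a number. The steps can therefore be read only as floors: an at least 1.0-fold higher number from compound 2 to compound 3 (0.03 log units; that floor lies within the scatter), and an at least 1.0-fold higher number from compound 1 to compound 3 (0.02 log units; that floor lies within the scatter). So on this amine nitrogen, a 4-methoxybenzyl arm, with its aromatic ring and no hydrogen-bond donor, brings no stronger inhibition than the two hydroxyalkyl arms, and a far larger change of arm than the earlier one still gives no gain.

The compounds shown leave open whether any other arm on this nitrogen can bring the number down. A carboxylic acid or a longer hydroxyalkyl chain would be one test of this.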